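This account rests on a few compounds, and the source may have more. Where it says the series, first, only, none or still open, it means among the compounds named here.

Working notes on the aryl amide series with the hexanoic acid chain.

Compound 1 is `CC(C)N(Cc1cccc(OCCCCCC(=O)O)c1)C(=O)c1ccc(-c2cccc3ccccc23)cc1`. In an ADME assay on Raji cells (Homo sapiens) for cytotoxicity, read by CellTiter-Glo and resazurin assay, with a stated time of 72 h (on this read-out lower numbers stand for an effect already at smaller amounts and higher numbers for an effect only at larger amounts of compound), compound 1 gives only a limit, > 26000 nM, and no number. Compound 2 is `CC(C)N(Cc1cccc(OCCCCCC(=O)O)c1)C(=O)c1ccc(-c2cccc(OCc3ccccc3)c2)cc1`; in this assay compound 2 likewise stops at the limit > 26000 nM. Compound 3 is `CC(C)N(Cc1cccc(OCCCCCC(=O)O)c1)C(=O)c1ccc(-c2cccc(OC(F)(F)F)c2)cc1`; in this assay compound 3 again gives the limit > 26000 nM and nothing more. The steps a step that the two limits leave unreadable from compound 1 to compound 3 and a step that the two limits leave unreadable from compound 2 to compound 3 are therefore not readable in size, since both ends are limits. The one thing the measured set shows is the limit of > 26000 nM in this assay, at which 3 of the 3 values shown sit, so within this set no change at the distal aryl position has yet produced a readable number in this assay.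

The compound to be measured next is compound 4, `CC(C)N(Cc1cccc(OCCCCCC(=O)O)c1)C(=O)c1ccc(-c2cccc(F)c2)cc1`. It differs from compound 1 by 3-fluorophenyl in place of naphthalen-1-yl on an aromatic carbon. Of the measured steps, only the ones from compound 1 and compound 2 toward compound 3 bear on an exchange at this position, and neither yields a size. On that basis the expected step that the limit leaves unreadable from compound 1 to compound 4 is one that again ends at a limit. For compound 4 in this assay the estimate is 30000 nM, with a range from 12000 nM to 80000 nM, and most likely only a limit will be reported.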

Compound 4, half-maximal effective concentration: > 26000 nM
Compound 4: a limit, no number (the forecaster's own chance of this, stated with the estimate: 80%); the middle value lies beyond the limit too.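

In this assay compound 4 gives only a limit and no number, so the steps to it from compound 1, compound 2 and compound 3 cannot be read in size. The compounds shown leave open whether any aryl group at this place on the shared core gives a readable number in this assay, and how far each of the four compounds lies past the limit.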